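The source may hold more compounds than are shown below. What is called first, only, known or untested is meant among the compounds shown, and "the series" means these compounds.

Of the compounds shown here, three built on one shared core have been tested in an ADME assay on BCBL1 cells (Homo sapiens) for cytotoxicity, with a stated time of 7 days; a higher number here means that more compound is tolerated, a lower number that less compound is tolerated. Compound 1 `COCCOc1nc(N)nc2c1ncn2/C=C1/CC1(CO)CO` reaches only the limit of the assay, giving > 20000 nM in this assay. Compound 2 `CCCCCCCCOc1nc(N)nc2c1ncn2/C=C1/CC1(CO)CO` likewise reports only a limit, > 20000 nM, in this assay. Compound 3 `CCCSc1nc(N)nc2c1ncn2/C=C1/CC1(CO)CO`, the starting point here, also ends at a limit in this assay, namely > 20000 nM. Because all three values sit at the same limit (the limit of > 20000 nM in this assay, at which 3 of the 3 values shown sit), none of the steps between them can be read: the step that the two limits leave unreadable from compound 1 to compound 2, the step that the two limits leave unreadable from compound 1 to compound 3 and the step that the two limits leave unreadable from compound 2 to compound 3 are each of unreadable size. Compound 4 `Nc1nc(NC2CCCC2)c2ncn(/C=C3/CC3(CO)CO)c2n1` differs from compound 3 in one place (cyclopentylamino in place of propylsulfanyl on an aromatic carbon). For the measured compounds named here, no measured step bears directly on this change, and the three unreadable steps give no direction either. The expectation is therefore that compound 4 also stays at the limit, with a step that the limit leaves unreadable from compound 3 to compound 4 that is estimated to lie within the usual scatter. Compound 4 is thus expected to give about 25000 nM in this assay, within a range from 8000 nM to 60000 nM.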

Compound 4, half-maximal cytotoxic concentration: 71700 nM
Estimate against measurement, compound 4: 2.9-fold (0.46 log units) below; measured number above the stated range.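

For the compounds shown here, compound 1, compound 2 and compound 3 stay at a limit in this assay, so no step from any of them to compound 4 can be read: the limit of > 20000 nM in this assay, at which 3 of the 4 values shown sit. The compounds shown leave open how far cyclopentylamino in place of propylsulfanyl actually shifts the tolerated concentration, or in which direction.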